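Bromine on the Phenol Ring of a Triazole-Bearing Core

A few compounds are considered here, and "the series" means these few. Any claim that something is new, unique, unknown or untested is made for them only; others in the source may bear on it.

Compound 1 `C=C1C[C@]23C[C@@]1(O)CC[C@H]2c1ccc(O)c(C)c1[C@@H]3Cn1cc(-c2ccccn2)nn1` in a functional assay on SMMC-7721 cells (Homo sapiens) for cytotoxicity, read by MTT assay, with a stated time of 4 days; a higher number here means a weaker inhibitor, a lower number a stronger inhibitor: > 20000 nM (a limit)
Compound 2 `C=C1C[C@]23C[C@@]1(O)CC[C@H]2c1ccc(O)c(C)c1[C@@H]3Cn1cc(-c2ccc(C(F)(F)F)cc2)nn1`: > 20000 nM (a limit)
Compound 3 `C=C1C[C@]23C[C@@]1(O)CC[C@H]2c1ccc(O)c(C)c1[C@@H]3Cn1cc(-c2ccc(F)cc2)nn1`: > 20000 nM (a limit)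

In this assay compound 2 gives only a limit of the measurement, > 20000 nM. Compound 1 and compound 3 sit at the same limit, as the limit of > 20000 nM in this assay, at which 3 of the 3 values shown sit, records. Compound 4 `C=C1C[C@]23C[C@@]1(O)CC[C@H]2c1cc(Br)c(O)c(C)c1[C@@H]3Cn1cc(-c2ccc(C(F)(F)F)cc2)nn1` differs from compound 2 by bromo in place of hydrogen on an aromatic carbon. Among the measured compounds shown here, no measured step touches this place: a step that the two limits leave unreadable from compound 1 to compound 2, a step that the two limits leave unreadable from compound 1 to compound 3 and a step that the two limits leave unreadable from compound 2 to compound 3 each run between two limits, so their size cannot be read. The measured steps therefore give no direction beyond the scatter. The step that the limit leaves unreadable from compound 2 to compound 4 is expected to stay within the scatter. Compound 4 is estimated at 25000 nM, between 8000 nM and 80000 nM, most likely again reported only as a limit.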

Compound 4, half-maximal inhibitory concentration: 12800 nM
Compound 4: middle estimate off by 2.0-fold (0.29 log units), on the high side; measured number inside the range.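

On an aromatic carbon ortho to a hydroxy group, bromo in place of hydrogen brings the first result in this assay that is a number and not a limit: the limit of > 20000 nM in this assay, at which 3 of the 4 values shown sit. With a limit on one side, the change reads as an at least 1.5-fold lower number from compound 2 to compound 4 (0.19 log units; that floor lies within the scatter). From the compounds shown here alone, its true size stays unknown, and the part that can be read does not go beyond the scatter.

Going by these compounds, whether bromo would also give a number on compound 1 or compound 3 remains open, as does whether chloro or an amine on this same carbon would do so.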